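Compound 3: One More Methoxy Added to Compound 1

A few compounds are considered here, and "the series" means these few. Any claim that something is new, unique, unknown or untested is made for them only; others in the source may bear on it.

Within the data shown here, compound 1 `COc1cc(OC)c(OC)cc1/C=C/C(=O)c1ccccc1F` gives 293 nM in a functional assay on HeLa cells (Homo sapiens) for cytotoxicity, read by MTT assay, with a stated time of 72 h (a higher number here means a weaker inhibitor, a lower number a stronger inhibitor), the highest of the two numbers measured so far; compound 2 `COc1ccc(OC)c(/C=C/C(=O)c2ccccc2F)c1` gives 96.1 nM, and the step of a 3.0-fold lower number from compound 1 to compound 2 (0.48 log units; beyond the scatter) removes a methoxy. Among the measured compounds shown here, compound 3 `COc1ccc(C(=O)/C=C/c2cc(OC)c(OC)cc2OC)c(F)c1` differs from compound 1 by methoxy in place of hydrogen on an aromatic carbon, a change on a different ring from the one where compound 2 loses its methoxy, so the only measured step does not bear directly on it. Compound 3 is therefore expected to shift little, a 1.2-fold lower number from compound 1 to compound 3 (0.07 log units; within the scatter), with an estimated 250 nM and a range from 100 nM to 700 nM.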

Compound 3, half-maximal inhibitory concentration: > 100000 nM
Compound 3: no number, only a limit; the forecaster's own chance of this, stated with the estimate: 3%; middle value at least 400-fold (2.60 log units) from the limit.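

Among these compounds, the first step on this ring shows that the position is far from indifferent: methoxy in place of hydrogen on an aromatic carbon, meta to a fluoro group and para to a large group, gives an at least 340-fold higher number from compound 1 to compound 3 (2.53 log units; beyond the scatter) in this assay. Among the compounds shown here, the only earlier step, a 3.0-fold lower number from compound 1 to compound 2 (0.48 log units; beyond the scatter), was modest and lay on the other ring. The value of compound 3 is a limit, not a number: the limit of > 100000 nM in this assay, at which 1 of the 3 values shown sits.

From the compounds shown here alone, whether a hydroxy group, an amine or a methyl group at this position would give a measurable number stays open. So does whether the same methoxy would have a like effect on compound 2.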